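The compounds below may be only part of what the source reports. "The series", "measured", "known", "first", "only" and "open" are said of these compounds alone.

Measured so far:
- compound 1, `CCc1ccc(NS(=O)(=O)c2ccc(N3CCNC3=O)cc2)cc1`: 660 nM
- compound 2, `COc1ccccc1NS(=O)(=O)c1ccc(N2CCNC2=O)cc1`: 550 nM
- compound 3, `Cc1cc(C)cc(NS(=O)(=O)c2ccc(N3CCNC3=O)cc2)c1`: 82 nM

All three share one core and differ only in the aryl group on the sulfonamide nitrogen. In a functional assay on HT-29 cells (Homo sapiens) for antiproliferative activity, read by sulforhodamine B assay, with a stated time of 48 h (on this read-out lower numbers stand for stronger inhibition and higher numbers for weaker inhibition), compound 3 stands lowest of the three, and both of its steps are beyond the scatter: an 8.0-fold lower number from compound 1 to compound 3 (0.91 log units; beyond the scatter) and a 6.7-fold lower number from compound 2 to compound 3 (0.83 log units; beyond the scatter). Compound 1 and compound 2 sit close together, a 1.2-fold lower number from compound 1 to compound 2 (0.08 log units; within the scatter).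

Compound 4, `O=C1NCCN1c1ccc(S(=O)(=O)Nc2ccccc2)cc1`, carries the change (phenyl in place of 3,5-dimethylphenyl on a sulfonamide nitrogen). Among the measured compounds shown here, no measured step removes substituents from the aryl ring outright, so the nearest guidance is that the 3,5-dimethylphenyl of compound 3 is the only variant that departs from the level of compound 1 and compound 2. Compound 4, lacking any substituent on that ring, is expected to fall back toward that level rather than keep the advantage of compound 3, giving a step of moderate size in this assay toward a higher number. The expected step is a 6.1-fold higher number from compound 3 to compound 4 (0.79 log units; beyond the scatter). Compound 4 is therefore estimated at 500 nM, with a range from 150 nM to 2000 nM.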

Compound 4, half-maximal inhibitory concentration: 280 nM
The estimate for compound 4 lay 1.8-fold (0.25 log units) above the measured number, within the range that was stated.
By their numbers in this assay, from the lowest: compound 3; then compounds 4, 2 and 1 (each within the scatter of the next, the first and the last beyond it).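

In this assay the plain phenyl on the sulfonamide nitrogen gives this position a reference point: compound 4 loses part of the advantage of the 3,5-dimethylphenyl (a 3.4-fold higher number from compound 3 to compound 4 (0.53 log units; beyond the scatter)), so that advantage depends on the two methyl groups. Against this reference, the methoxy of compound 2 gives no separable change (a 2.0-fold lower number from compound 2 to compound 4 (0.29 log units; within the scatter)), whereas replacing the ethyl of compound 1 with hydrogen gives a real gain (a 2.4-fold lower number from compound 1 to compound 4 (0.37 log units; beyond the scatter)), so among the substituted rings shown only the 3,5-dimethylphenyl improves on phenyl. No measurement here accounts for these differences.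

Still open, from the compounds shown here alone, is whether a single methyl group keeps part of the gain, or whether a 3,5-diethylphenyl extends it. How an amine or a carboxylic acid on the ring would read is also unknown.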